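This account rests on a few compounds, and the source may have more. Where it says the series, first, only, none or still open, it means among the compounds named here.

Measured compounds and their values in an assay on Sf9 cells for inhibition of inhibitor of nuclear factor kappa-B kinase subunit epsilon (Homo sapiens), read by ADP-Glo, with a stated time of 60 min; on this read-out lower numbers stand for stronger inhibition and higher numbers for weaker inhibition:

compound 1, `CC(=O)n1nc(C)c(-c2ccc(Cl)c(Cl)c2)c1N`: > 100000 nM
compound 2, `Cc1nn(C(=O)C2CCC2)c(N)c1-c1ccc(Cl)c(Cl)c1`: > 100000 nM
compound 3, `CC(=O)n1nc(N)c(-c2ccc(Cl)c(Cl)c2)c1C`: > 100000 nM

Each of these three values is a limit of the assay and not a number. For compound 1 the reading > 100000 nM is such a limit. For compound 2 the reading > 100000 nM is likewise a limit. For compound 3 the reading > 100000 nM is a limit as well, which is to say that (the limit of > 100000 nM in this assay, at which 3 of the 3 values shown sit).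

Compound 2 arises from compound 1 by cyclobutyl in place of methyl on a carbonyl carbon. In this assay this gives a step that the two limits leave unreadable from compound 1 to compound 2, because both readings sit at the limit of > 100000 nM in this assay, at which 3 of the 3 values shown sit. Compound 3 carries the same atoms as compound 1 joined differently; the difference between the two cores is not broken down here.

Compound 4, `Cc1c(-c2ccc(Cl)c(Cl)c2)c(N)nn1C(=O)C1CCC1`, has not been measured. It arises from compound 3 by cyclobutyl in place of methyl on a carbonyl carbon, the same change as that from compound 1 to compound 2. Since that earlier step could not be read, and since both compound 1 and compound 3 sit at the limit of > 100000 nM in this assay, at which 3 of the 3 values shown sit, the expected step in this assay is a step that the limit leaves unreadable from compound 3 to compound 4, with no number readable on either end. The estimate for compound 4 is therefore 150000 nM, with an expected range from 50000 nM to 500000 nM, and most likely the assay will again report only a limit.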

Compound 4, half-maximal inhibitory concentration: > 100000 nM
Compound 4: a limit, no number; the forecaster's own chance of this, stated with the estimate: 90%; the middle value does not contradict the limit.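

In this assay compound 4 gives > 100000 nM, which is a limit of the assay and not a number. No step can be read between compound 3 and compound 4, because both sit at the same limit: the limit of > 100000 nM in this assay, at which 4 of the 4 values shown sit.

The compounds shown leave open how strongly any of the four inhibits this kinase, and whether cyclobutyl in place of methyl on the carbonyl carbon changes that at all.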